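Fluoro for ethyl on the anilide ring of compound 1

This account rests on a few compounds, and the source may have more. Where it says the series, first, only, none or still open, it means among the compounds named here.

Compound 1 (`CCc1cccc(NC(=O)N[C@H](C)c2ccccc2)c1`) is the lowest of the three numbers in an ADME assay on the whole organism with Oryza sativa as the target, tested at 10 uM; on this read-out higher numbers stand for a weaker effect at the one concentration tested and lower numbers for a stronger effect: compound 1 gives 36%. Its nearest neighbour is compound 3 (`CCCc1ccc(NC(=O)N[C@@H](C)c2ccccc2)cc1`), which gives 73% in this assay, and the furthest is compound 2 (`CCc1cccc(NC(=O)N[C@@H](C)c2ccccc2)c1`), which gives 86%. Among the measured compounds shown here, the one measured step, a number 50 percentage points higher from compound 1 to compound 2 (beyond the scatter), rests only on the fact that compounds 1 and 2 differ only in the configuration as drawn and touches no group on the aromatic ring.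

Compound 4 (`C[C@@H](NC(=O)Nc1cccc(F)c1)c1ccccc1`) changes a different place: fluoro in place of ethyl on an aromatic carbon. For the measured compounds named here, no measured step concerns a change on that ring, so none bears directly on this one; the step between the two stereoisomers gives no guide for swapping one aromatic substituent for another, and the gap between compound 1 and compound 3 mixes a ring change with a change of configuration.

With nothing to lean on, he expects the step of a number 9 percentage points higher from compound 1 to compound 4 (within the scatter) to be uncertain in direction, and estimates for compound 4 a value of 45% in this assay, within 20% to 80%.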

Compound 4, a percentage reported as activity, at one concentration (the size of the read-out at that concentration, not a potency): 84%
Estimate against measurement, compound 4: 39 percentage points below; measured number above the stated range.
By their numbers in this assay, from the lowest: compound 1; then compound 3; then compounds 4 and 2 (each within the scatter of the next).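

Placing fluoro where ethyl stood, on an aromatic carbon meta to a large group, gives in this assay a number 48 percentage points higher from compound 1 to compound 4 (beyond the scatter). The low number of compound 1 therefore does not survive a change at this ring position, whereas the earlier compounds had shown only that it does not survive a change of configuration as drawn, with a number 50 percentage points higher from compound 1 to compound 2 (beyond the scatter). Nothing shown here accounts for the size of the step on the ring.

As far as these compounds go, it remains open whether a methyl, a chloro, a methoxy or a propyl group at this same position would keep the low number of compound 1 or lose it as fluoro does. Also open, from the compounds shown here alone, is how fluoro or an amine at this position would read in the opposite configuration as drawn.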